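A Single Aromatic Swap and Its Expected Cytotoxic Outcome

The source may report more compounds than this note shows. Statements on the series, on what has been measured and on what is new or still open speak of the compounds shown alone.

The series shares one core, seen in compound 1 `O=c1ccc2cc(OCc3cc(-c4ccc([N+](=O)[O-])cc4)no3)ccc2o1` and in compound 2 `O=c1ccc2cc(OCc3cn(-c4cccc(CO)c4)nn3)ccc2o1`. In a functional assay on A549 cells (Homo sapiens) for cytotoxicity, read by MTT assay, with a stated time of 48 h (a lower number here means a stronger inhibitor, a higher number a weaker inhibitor), compound 1 gives "not determined" (no result reported), so no result was reported for it. In this assay, going by the values given here, compound 2 gives 35100 nM, which is the only number available, so it is weak in absolute terms but cannot be placed against any other measured member.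

Compound 3 `O=c1ccc2cc(OCc3cn(-c4ccccc4[N+](=O)[O-])nn3)ccc2o1` carries the change (2-nitrophenyl in place of 3-(hydroxymethyl)phenyl on an aromatic nitrogen). Among the compounds with values here, no measured pair that differs only in this way exists, so there is no observed step to lean on. With nothing else measured, the most cautious view is that the new group does not shift potency far beyond the usual scatter in either direction, although a modest change cannot be excluded.

Compound 3 is therefore expected to give about 40000 nM in this assay, with a plausible spread from 10000 nM to 160000 nM. The step of a 1.1-fold higher number from compound 2 to compound 3 (0.06 log units; within the scatter) is estimated to be small, and the expected number stays in the weak range where compound 2 already sits with 35100 nM.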

Compound 3, half-maximal inhibitory concentration: 10200 nM
Compound 3: the middle estimate sits 3.9-fold (0.59 log units) above what was measured; the measured number falls inside the stated range.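

In this assay, the group on the aromatic nitrogen of the triazole-type ring, the five-membered aromatic ring with 3 nitrogen, proves able to move the read-out: putting 2-nitrophenyl in place of 3-(hydroxymethyl)phenyl gives a 3.4-fold lower number from compound 2 to compound 3 (0.54 log units; beyond the scatter) and so a real, if modest, gain in potency. Going by these compounds alone, this is the first comparison the series allows, since compound 1 has no reported result and compound 2 alone could say nothing about how much this position matters. The step also shows that the hydroxymethyl group is not needed for activity in this pair, as compound 3 lacks it and remains active, though still far from strong.

The swap removes the hydroxymethyl group, brings in a nitro group and changes where the substituent stands on the phenyl ring all at once, so the compounds shown do not tell which of these carries the step, and a plain phenyl, or a phenyl bearing an amine or a carboxylic acid, would be needed to pull them apart. Nothing measured here speaks to why the number moved.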